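The compounds below may be only part of what the source reports. "The series", "measured", "known", "first", "only" and "open" are said of these compounds alone.

Measured in a functional assay on A549 cells (Homo sapiens) for antiproliferative activity, read by MTT assay, with a stated time of 72 h; on this read-out lower numbers stand for stronger inhibition and higher numbers for weaker inhibition:
compound 1 `CCCCc1cn(C[C@H](O)[C@H]2OC(=O)C(OCc3ccccc3)=C2OCc2ccccc2)nn1` gives 28600 nM
compound 2 `O=C1O[C@H]([C@@H](O)Cn2cc(-c3cc(F)cc(F)c3)nn2)C(OCc2ccccc2)=C1OCc1ccccc1` gives 41200 nM
compound 3 `Cc1ccc(S(=O)(=O)NCc2cn(C[C@H](O)[C@H]3OC(=O)C(OCc4ccccc4)=C3OCc3ccccc3)nn2)cc1` gives 16800 nM

Compound 3 gives the lowest number of the three, though the gap to compound 1 is within the scatter; only a 2.5-fold lower number from compound 2 to compound 3 (0.39 log units; beyond the scatter) goes beyond it. Compound 4 `COc1ccc(-c2cn(C[C@H](O)[C@H]3OC(=O)C(OCc4ccccc4)=C3OCc3ccccc3)nn2)cc1` differs from compound 3 by 4-methoxyphenyl in place of (((4-methylphenyl)sulfonyl)amino)methyl on an aromatic carbon. Among the measured compounds shown here, the closest precedent runs the other way, an aryl group on that carbon giving way to the sulfonamide-bearing chain: a 2.5-fold lower number from compound 2 to compound 3 (0.39 log units; beyond the scatter). Between the two aryl-bearing compounds, a 1.4-fold higher number from compound 1 to compound 2 (0.16 log units; within the scatter), so exchanging one aryl for another has done little here. In this assay compound 4 is therefore expected to drift back toward the aryl pair, with a 1.9-fold higher number from compound 3 to compound 4 (0.28 log units; within the scatter). The estimate for compound 4 is 32000 nM, within 15000 nM to 70000 nM.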

Compound 4, half-maximal inhibitory concentration: 28300 nM
Beside the measured number, compound 4's estimate is 1.1-fold (0.05 log units) above it; the measured number falls inside the stated range.
By their numbers in this assay, from the lowest: compounds 3, 4, 1 and 2 (each within the scatter of the next, the first and the last beyond it).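

In this assay the 4-methoxyphenyl group, on the aromatic carbon of the five-membered aromatic ring with 3 nitrogen, sits within the scatter of every earlier group: a 1.7-fold higher number from compound 3 to compound 4 (0.23 log units; within the scatter) and a 1.5-fold lower number from compound 2 to compound 4 (0.16 log units; within the scatter) and a 1.0-fold lower number from compound 1 to compound 4 (0.00 log units; within the scatter) all stay inside it. Among the compounds shown here, compound 4 therefore falls between compound 2 and compound 3, the only pair printed as beyond the scatter, and does not widen the range. Compound 4 also shows that an aryl group here need not sit apart from the sulfonamide-bearing compound 3.

From the compounds shown here alone, whether an amine, a carboxylic acid or a chain longer than butyl at this carbon would leave this range stays open. No measurement bearing on the reason for these small gaps is at hand.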